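Hydroxy to cyano on the core of compound 1

The compounds below may be only part of what the source reports. "The series", "measured", "known", "first", "only" and "open" are said of these compounds alone.

Measured in a functional assay on U-937 cells (Homo sapiens) for antiproliferative activity, with a stated time of 48 h; on this read-out higher numbers stand for an effect only at larger amounts of compound and lower numbers for an effect already at smaller amounts:
compound 1 `O=C(CCCCCCC(=O)Nc1ccc(O)cc1)NO`: 6400 nM
compound 2 `O=C(CCCCCCC(=O)Nc1cccc(F)c1)NO`: 500 nM
compound 3 `O=C(CCCCCCC(=O)Nc1cccc(Cl)c1)NO`: 350 nM

Compound 1 stands highest of the three at 6400 nM. Compound 4 `N#Cc1ccc(NC(=O)CCCCCCC(=O)NO)cc1` has not yet been measured. It differs from compound 1 as follows: cyano in place of hydroxy on an aromatic carbon. In words, cyano replaces hydroxy on an aromatic carbon, para to a large group. For the measured compounds named here, the only measured step, a 1.4-fold lower number from compound 2 to compound 3 (0.15 log units; within the scatter), lies within the scatter and does not involve hydroxy or cyano, so it bears on this change only indirectly. Neither compound 2 at 500 nM nor compound 3 at 350 nM carries the hydroxy, and both show far lower numbers than compound 1 . Going by the values given here, no measured compound carries cyano, so the expectation is loose. A clearly lower number is expected, an estimated 8.0-fold lower number from compound 1 to compound 4 (0.90 log units; beyond the scatter). For compound 4 the estimate is 800 nM, with an expected range from 250 nM to 2500 nM.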

Compound 4, half-maximal effective concentration: 7000 nM
Compound 4: middle estimate off by 8.8-fold (0.94 log units), on the low side, outside the stated range (above it).
By their numbers in this assay, from the lowest: compounds 3 and 2 (each within the scatter of the next); then compounds 1 and 4 (each within the scatter of the next).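

In this assay, cyano in place of hydroxy on an aromatic carbon, para to a large group, gives a 1.1-fold higher number from compound 1 to compound 4 (0.04 log units; within the scatter). At this position the two groups cannot be told apart on this read-out, although the hydroxy carries a hydrogen-bond donor and cyano carries none. Nothing at hand accounts for this result.

The compounds shown leave open whether an amine or a carboxylic acid at this position would change the number. They also leave open whether fluoro or chloro placed here would give a number unlike that of compound 1.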